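Compound 3 to compound 4: a shorter side group

This account rests on a few compounds, and the source may have more. Where it says the series, first, only, none or still open, it means among the compounds named here.

Measured in a functional assay with Oryctolagus cuniculus as the target; on this read-out lower numbers stand for stronger inhibition and higher numbers for weaker inhibition:
- Compound 1 `COc1ccc(-c2nc(/N=C(\N)NC(C)C)sc2-c2ccc(OC)cc2)cc1`: > 100 nM, a limit and not a number
- Compound 2 `COc1ccc(-c2nc(/N=C(\N)n3ccnc3)sc2-c2ccc(OC)cc2)cc1`: > 100 nM, a limit and not a number
- Compound 3 `COc1ccc(-c2nc(CNC(=O)c3cccnc3)sc2-c2ccc(OC)cc2)cc1`: 25 nM

Among the compounds with values here, compound 3 holds the only true number in the set, while the other two compounds stand at the limit of > 100 nM in this assay, at which 2 of the 3 values shown sit.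

Compound 4 `COc1ccc(-c2nc(C(=O)N(C)C)sc2-c2ccc(OC)cc2)cc1` has not yet been measured. It differs from compound 3 as follows: dimethylcarbamoyl in place of (((pyridin-3-yl)carbonyl)amino)methyl on an aromatic carbon.

Within the data shown here, two measured steps bear on this change: an at least 4.0-fold lower number from compound 1 to compound 3 (0.60 log units; beyond the scatter) and an at least 4.0-fold lower number from compound 2 to compound 3 (0.60 log units; beyond the scatter). Both end on the group that compound 4 gives up, so a move back toward a higher number is expected. Neither step involves dimethylcarbamoyl, and both are bounded by a limit, so the size remains loosely held.

In this assay the expected step is a 2.4-fold higher number from compound 3 to compound 4 (0.38 log units; beyond the scatter).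

For compound 4 the estimate is 60 nM, with an expected range of 10 nM to 300 nM.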

Compound 4, half-maximal inhibitory concentration: < 100 nM
Compound 4 gave a limit, no number; the forecaster's own chance of this, stated with the estimate: 35%; the middle value lies beyond the limit too.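

In this assay compound 4 gives < 100 nM, a limit and not a number. Its limit points the opposite way from those of compound 1 and compound 2, so on this aromatic carbon neither the ring of (((pyridin-3-yl)carbonyl)amino)methyl nor a hydrogen-bond donor is needed to reach that side, as dimethylcarbamoyl with no ring and no donor gets there too. That gives a number no higher from compound 1 to compound 4 (the limit leaves the size open) and a number no higher from compound 2 to compound 4 (the limit leaves the size open). The step from compound 3 to compound 4 cannot be read because compound 4 carries a limit: the limit of < 100 nM in this assay, at which 1 of the 4 values shown sits.

Where compound 4 stands relative to compound 3 stays open, so the cost or gain of the shorter group is unknown. Also open, as far as these compounds go, is whether a carboxylic acid or a primary amine on this aromatic carbon would fall on the same side as dimethylcarbamoyl.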